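The compounds below may be only part of what the source reports. "The series", "measured", "known", "first", "only" and "open" are said of these compounds alone.

Compound 1 `CC(=O)c1cc(-c2ccccc2)cc2cc(-c3ccccc3)[nH]c12`: in a functional assay on MCF7 cells (Homo sapiens) for cytotoxicity, read by MTT assay, with a stated time of 2 days, tested at 10 uM (on this read-out lower numbers stand for a stronger effect and higher numbers for a weaker effect at the one concentration tested), compound 1 gives 96.2%
Compound 2 `CC(=O)c1cc(-c2ccc(F)cc2)cc2cc(-c3ccccc3)[nH]c12`: in this assay compound 2 gives 73.8%

Of these two numbers compound 1 stands highest, meaning the weaker effect at the tested concentration. For the measured compounds named here, the only measured step, a number 22.4 percentage points lower from compound 1 to compound 2 (beyond the scatter), shows that fluoro in place of hydrogen on an aromatic carbon of one phenyl lowered the read-out by a modest amount.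

Compound 3 `CC(=O)c1cc(-c2ccccc2)cc2cc(-c3ccc(F)cc3)[nH]c12` is not yet measured. It differs from compound 1 by fluoro in place of hydrogen on an aromatic carbon, so the same kind of exchange is made, but on the other phenyl of the shared core. Going by the values given here, only the step from compound 1 to compound 2 bears on this, and it was modest. A step of similar direction is therefore expected, though its size at this other place is uncertain, so the expected step is a number 14.2 percentage points lower from compound 1 to compound 3 (beyond the scatter). Compound 3 is estimated at 82%, likely between 65% and 98%.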

Compound 3, a percentage reported as activity, at one concentration (the size of the read-out at that concentration, not a potency): 91.9%
Estimate against measurement, compound 3: 9.9 percentage points below, and the stated range covers the measured number.
By their numbers in this assay, from the lowest: compound 2; then compounds 3 and 1 (each within the scatter of the next).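

Fluoro in place of hydrogen on this other phenyl gives a number 4.3 percentage points lower from compound 1 to compound 3 (within the scatter) in this assay, so at this place the exchange cannot be told apart from no change. The same exchange on the first phenyl gave a number 22.4 percentage points lower from compound 1 to compound 2 (beyond the scatter), so across these two steps the outcome depends on which phenyl carries the fluoro. Nothing available explains why the two places differ.

Still open, as far as these compounds go, is whether a different group at this place, such as a methoxy group or an amine, would move the read-out beyond the scatter. Also open, from the compounds shown here alone, is what a compound with a 4-fluorophenyl in both places would give, and whether the two exchanges would add up.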